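Swapping Nitro for Trifluoromethyl on a Dichloroacetanilide

The compounds below may be only part of what the source reports. "The series", "measured", "known", "first", "only" and "open" are said of these compounds alone.

Three small amides share one core. Compound 1 `O=C(Nc1cccc(F)c1)C(Cl)Cl` has no result in a functional assay on KB cells (Homo sapiens) for antiproliferative activity, read by MTT assay, with a stated time of 72 h; on this read-out higher numbers stand for weaker inhibition and lower numbers for stronger inhibition; for compound 1 the record simply reads "not determined" (no result reported). In this assay, among the measured compounds shown here, compound 2 `O=C(Nc1cccc([N+](=O)[O-])c1)C(Cl)Cl` gives 44700 nM, the only number available here, and that number stands for weak inhibition. Compound 3 `O=C(Nc1cccc(C(F)(F)F)c1)C(Cl)Cl` differs from it by trifluoromethyl in place of nitro on an aromatic carbon. For the measured compounds named here, no measured pair covers this change, so the expectation rests on compound 2 alone. The step is expected to be small, a 1.1-fold higher number from compound 2 to compound 3 (0.05 log units; within the scatter), not beyond the usual scatter. Compound 3 is therefore expected to give 50000 nM, with a range from 15000 nM to 160000 nM.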

Compound 3, half-maximal inhibitory concentration: 8860 nM
Compound 3: the middle estimate sits 5.6-fold (0.75 log units) above what was measured, and the stated range ends above it.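

In this assay, the group on this aromatic carbon matters: trifluoromethyl in place of nitro gives a 5.0-fold lower number from compound 2 to compound 3 (0.70 log units; beyond the scatter), a shift toward stronger inhibition that repeat measurements alone would not explain. So this position does not treat these two groups alike, even with the rest of the molecule unchanged. Nothing available here accounts for the difference.

From the compounds shown here alone, whether the trend holds beyond these two groups remains open. An amine, a carboxylic acid or a longer carbon chain on the same aromatic carbon would test how far it extends.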